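A few compounds are considered here, and "the series" means these few. Any claim that something is new, unique, unknown or untested is made for them only; others in the source may bear on it.

Within the data shown here, compound 1 `COc1cc(OC)c(/C=C/S(=O)(=O)Cc2ccc(C#N)cc2)c(OC)c1` is the one compound of the series with a number: in a functional assay on DU-145 cells (Homo sapiens) for antiproliferative activity, read by trypan blue exclusion (on this read-out lower numbers stand for stronger inhibition and higher numbers for weaker inhibition), compound 1 gives 7500 nM. Compound 2 `COc1ccc(CS(=O)(=O)/C=C/c2cc(C)cc(C)c2)cc1` reaches only a limit of the assay, > 20000 nM in this assay. Compound 3 `COc1ccc(CS(=O)(=O)/C=C/c2c(C)cccc2C)cc1` likewise sits at a limit, > 20000 nM in this assay. Thus the limit of > 20000 nM in this assay, at which 2 of the 3 values shown sit, marks where two of the three values stand, and no step between measured compounds can be read from them.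

Compound 4 `COc1ccc(CS(=O)(=O)/C=C/c2c(OC)cc(OC)cc2OC)cc1` differs from compound 1 by methoxy in place of cyano on an aromatic carbon. Among the measured compounds shown here, no measured pair shows this change, so the expected step from compound 1 to compound 4 is a 1.3-fold lower number from compound 1 to compound 4 (0.10 log units; within the scatter), a shift not clearly beyond the scatter. Compound 4 is estimated at 6000 nM, within 2000 nM to 20000 nM.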

Compound 4, half-maximal inhibitory concentration: 25 nM
The estimate for compound 4 lay 240-fold (2.38 log units) above the measured number; the measured number lies below the stated range.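

Methoxy in place of cyano on an aromatic carbon para to a large group gives a 300-fold lower number from compound 1 to compound 4 (2.48 log units; beyond the scatter), so this position strongly affects the read-out, which compound 1 alone could not show. The two groups match in heavy atoms and hydrogen-bond acceptors, so those counts do not follow the step. Nothing measured here speaks to why the step is so large.

On these data alone, whether an amine, a carboxylic acid or a hydroxyl at this position would keep the lower number stays open. Also open, as far as these compounds go, is whether the step holds on any core other than that of compound 1.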